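A few compounds are considered here, and "the series" means these few. Any claim that something is new, unique, unknown or untested is made for them only; others in the source may bear on it.

Within the data shown here, compound 2, `C#Cc1cncc(OC[C@@H]2CCCN2C)c1`, gives 8.2 nM in an assay on a protein complex for binding affinity to Neuronal acetylcholine receptor; alpha3/beta2 (Homo sapiens) (on this read-out lower numbers stand for stronger inhibition and higher numbers for weaker inhibition), the lowest of the two numbers measured so far. Its neighbour is compound 1, `CN1CCC[C@H]1COc1cncc(C#CCCCCF)c1`, which in this assay gives 14 nM; the step from compound 1 to compound 2 reads a 1.7-fold lower number from compound 1 to compound 2 (0.23 log units; within the scatter). Compound 3, `CN1CCC[C@H]1COc1cncc(C#CCCCCO)c1`, has not yet been measured in this assay. It differs from compound 2 by 4-hydroxybutyl in place of hydrogen on a triple-bonded carbon. Among the measured compounds shown here, the only measured step that bears on this change is the one from compound 1 to compound 2, where a 4-fluorobutyl group on the same triple-bonded carbon was replaced by hydrogen and the number moved by a 1.7-fold lower number from compound 1 to compound 2 (0.23 log units; within the scatter). Since that chain made no difference beyond the scatter, a similar chain carrying a hydroxyl end is expected to leave the number close to where compound 2 stands, with a step of a 1.5-fold higher number from compound 2 to compound 3 (0.17 log units; within the scatter). Compound 3 is therefore expected to give about 12 nM, between 5 nM and 30 nM.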

Compound 3, inhibition constant: 13 nM
Estimate against measurement, compound 3: 1.1-fold (0.03 log units) below, within the range that was stated.
By their numbers in this assay, from the lowest: compounds 2, 3 and 1 (each within the scatter of the next).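

In this assay, a second chain on the triple-bonded carbon, 4-hydroxybutyl, also leaves the number within the scatter (a 1.6-fold higher number from compound 2 to compound 3 (0.20 log units; within the scatter)), so the tolerance seen with 4-fluorobutyl is not confined to that one chain. Changing only the chain end, hydroxy in place of fluoro on a saturated chain carbon, four bonds along the chain from a triple-bonded carbon, has no effect beyond the scatter either (a 1.1-fold lower number from compound 1 to compound 3 (0.03 log units; within the scatter)), and so these two chain ends cannot be told apart here. No measurement at hand explains why the numbers stay so close.

On these data alone, whether the same holds for an amine or a carboxylic acid at the chain end remains open. So does the outcome with a longer chain, or with a ring in place of the chain on this carbon.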